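The compounds below may be only part of what the source reports. "The series", "measured", "known", "first", "only" and "open" are said of these compounds alone.

Compound 1 `COc1cc(/C=C/c2ccc(NC(=O)/C=C/c3ccc(OC)c(OC)c3)cc2)cc(OC)c1` is the starting point, and in a functional assay on MDA-MB-231 cells (Homo sapiens) for inhibition, read by MTT assay, with a stated time of 48 h (a higher number here means a weaker inhibitor, a lower number a stronger inhibitor), compound 1 gives 7740 nM. Compound 2 `COc1cc(/C=C/c2ccc(NC(=O)/C=C/c3ccc(C#N)cc3)cc2)cc(OC)c1` carries a 4-cyanophenyl in place of the 3,4-dimethoxyphenyl, and in this assay compound 2 gives 7740 nM, so compound 1 and compound 2 stand level at the digits shown. The unmeasured compound 3 `COc1cc(/C=C/c2ccc(NC(=O)/C=C/c3ccc(Br)cc3)cc2)cc(OC)c1` differs from compound 1 as follows: 4-bromophenyl in place of 3,4-dimethoxyphenyl on a double-bonded chain carbon bound to a double-bonded chain carbon. Among the measured compounds shown here, the one measured step that bears on this, a swap of the same 3,4-dimethoxyphenyl for another group on the same double-bonded chain carbon, was no change at the digits printed from compound 1 to compound 2 (within the scatter), which lies within the scatter. Nothing measured here separates a 4-bromophenyl from a 4-cyanophenyl, so no step beyond the scatter is expected for a 1.0-fold lower number from compound 1 to compound 3 (0.00 log units; within the scatter). Compound 3 is therefore estimated at 7700 nM in this assay, with a likely range from 3000 nM to 20000 nM.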

Compound 3, half-maximal inhibitory concentration: 6160 nM
For compound 3 the middle estimate is 1.3-fold (0.10 log units) above the measured one, within the range that was stated.
By their numbers in this assay, from the lowest: compounds 3, 1 and 2 (each within the scatter of the next).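

In this assay, a second replacement for the 3,4-dimethoxyphenyl on this double-bonded chain carbon, the 4-bromophenyl, gives a 1.3-fold lower number from compound 1 to compound 3 (0.10 log units; within the scatter). Bromo in place of cyano on an aromatic carbon gives a 1.3-fold lower number from compound 2 to compound 3 (0.10 log units; within the scatter), so three different aromatic groups at this place now stand within the scatter of one another, and the two replacements cannot be told apart. Nothing available explains why these groups read alike.

Going by these compounds, all three compounds carry a substituted phenyl at this place, so it remains open whether an amine or a carboxylic acid on that ring would also stay within the scatter. The compounds shown also say nothing about changes elsewhere in the shared core, such as to the amide hydrogen or the methoxy groups.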